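A Methyl Added to the Core of Compound 1

The compounds below may be only part of what the source reports. "The series", "measured", "known", "first", "only" and "open" are said of these compounds alone.

Compound 1 `CCCCCCCCCCn1cc(Cn2cnc3nc(-c4ccccc4)cc(C(F)(F)F)c3c2=O)nn1` was tested in a functional assay on THP-1 cells (Homo sapiens) for cytotoxicity, read by MTT assay, with a stated time of 24 h (a higher number here means a weaker inhibitor, a lower number a stronger inhibitor), where compound 1 gives 16.9 ug/mL. That is the only numerical result shown for the series. Compound 2 `Cc1nc2nc(-c3ccccc3)cc(C(F)(F)F)c2c(=O)n1Cc1cn(CCC(F)(F)C(F)(F)C(F)(F)C(F)(F)C(F)(F)C(F)(F)F)nn1` carries a methyl together with a fluorinated chain in place of the decyl chain, and in this assay compound 2 reaches only a limit of the assay, > 200 ug/mL. Going by the values given here, the entry the limit of > 200 ug/mL in this assay, at which 1 of the 2 values shown sits, is the sole further value. Among the compounds with values here, compound 2 differs from compound 1 in two places at once, and no single step between measured compounds is available.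

Compound 3 `CCCCCCCCCCn1cc(Cn2c(C)nc3nc(-c4ccccc4)cc(C(F)(F)F)c3c2=O)nn1` differs from compound 1 in one place: methyl in place of hydrogen on an aromatic carbon. Compound 2, which also carries a methyl, offers no clean comparison, as its chain differs as well. For a change of a single methyl, no step beyond the usual scatter is expected in this assay in either direction. For compound 3 the expected value in this assay is 25 ug/mL, within a range from 10 ug/mL to 80 ug/mL. That estimate means an expected step from compound 1 to compound 3 of a 1.5-fold higher number from compound 1 to compound 3 (0.17 log units; within the scatter), falling inside the scatter.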

Compound 3, half-maximal inhibitory concentration: 11.3 ug/mL
Beside the measured number, compound 3's estimate is 2.2-fold (0.34 log units) above it; low and high end bracket the measured number.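

In this assay, placing a methyl in place of hydrogen on the aromatic carbon between two ring nitrogen atoms gives a 1.5-fold lower number from compound 1 to compound 3 (0.17 log units; within the scatter), so with the decyl chain held constant, this single change does not separate the two compounds. Going by these compounds alone, this is the first comparison that isolates one place, and it shows that this carbon of the shared core accepts a methyl without a step beyond the scatter in this cytotoxicity read-out. The compounds shown offer no measured property that would explain the size of this step, and the limit recorded for compound 2 does not bear on it.

On these data alone, what a larger or differently built group would do on this same carbon stays open, for instance an ethyl group, a phenyl ring or an amine. Also open, as far as these compounds go, is how compound 3 would read with the decyl chain replaced by a shorter octyl chain or a longer dodecyl chain, since a single methyl says little about either change.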